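A New Side Chain on Compound 3

This account rests on a few compounds, and the source may have more. Where it says the series, first, only, none or still open, it means among the compounds named here.

In an ADME assay (Homo sapiens) for cytotoxicity (on this read-out lower numbers stand for higher toxicity in this test and higher numbers for lower toxicity in this test), compound 1 (`Nc1nn2c(O)cc(-c3cc([N+](=O)[O-])c(Cl)cc3Cl)nc2c1[N+](=O)[O-]`) gives > 100 ug/mL, which is a limit of the assay. Compound 2 (`Nc1nn2c(O)cc(-c3ccc(F)cc3)nc2c1[N+](=O)[O-]`) gives > 100 ug/mL, also a limit. Compound 3 (`Nc1nn2c(O)cc(CCl)nc2c1[N+](=O)[O-]`) gives > 50 ug/mL, again only a limit, so no number fixes where it stands. Compound 4 (`Nc1nn2c(O)cc(CNNCCO)nc2c1[N+](=O)[O-]`) differs from it as follows: ((2-hydroxyethyl)amino)amino in place of chloro on a saturated chain carbon bound to an aromatic carbon. Going by the values given here, the one measured step at the same chain position, a step that the two limits leave unreadable from compound 2 to compound 3, gives no size to carry over, and the evidence consists of limits alone: the limit of > 100 ug/mL in this assay, at which 2 of the 3 values shown sit, and (the limit of > 50 ug/mL in this assay, at which 1 of the 3 values shown sits). No change beyond the scatter is therefore expected in this assay, and the expected step is a step that the limit leaves unreadable from compound 3 to compound 4. For compound 4 the estimated value is 100 ug/mL, within an expected range of 40 ug/mL to 200 ug/mL.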

Compound 4, half-maximal cytotoxic concentration: > 50 ug/mL
Compound 4: a limit, no number; the forecaster's own chance of this, stated with the estimate: 70%; the middle value lies beyond the limit too.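

Going by these compounds alone, compound 4 gives only a limit, as do compound 2 and compound 3, so no step from either of them to compound 4 can be read. In this assay the compounds shown leave open at what concentration any of them becomes cytotoxic.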